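The source may report more compounds than this note shows. Statements on the series, on what has been measured and on what is new or still open speak of the compounds shown alone.

Working notes on the series. Compound 1 `N#CC1=C(N)N(c2ccc(S(N)(=O)=O)cc2)C2=C(C(=O)CCC2)C1/C=C/c1ccccc1` carries 2-phenylethenyl on a saturated ring carbon of the shared core, while compound 2 `COc1ccc(C2C(C#N)=C(N)N(c3ccc(S(N)(=O)=O)cc3)C3=C2C(=O)CCC3)cc1` carries 4-methoxyphenyl at that carbon. In a functional assay on Ehrlich cells (Mus musculus) for antiproliferative activity, read by trypan blue exclusion, with a stated time of 2 h, tested at 100 ug/mL (on this read-out lower numbers stand for a weaker effect and higher numbers for a stronger effect at the one concentration tested), compound 1 gives 45% and compound 2 gives 100%, the higher of the two numbers; the step is a number 55 percentage points higher from compound 1 to compound 2 (beyond the scatter). Compound 3 `COc1cc(CC2C(C#N)=C(N)N(c3ccc(S(N)(=O)=O)cc3)C3=C2C(=O)CCC3)ccc1O` differs from compound 2 in one place: 4-hydroxy-3-methoxybenzyl in place of 4-methoxyphenyl on a saturated ring carbon. Among the compounds with values here, the only measured step bearing on this position is that from compound 1 to compound 2, which was large, so the group on this saturated ring carbon clearly matters to the read-out. Within the data shown here, no measured pair shows how a benzyl group compares with a phenyl group here, and compound 2 already sits at the top of the range, leaving room only downward. Compound 3 is therefore expected to come out somewhat lower, a number 20 percentage points lower from compound 2 to compound 3 (beyond the scatter), at an estimated 80% with a range from 50% to 100%.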

Compound 3, a percentage reported as activity, at one concentration (the size of the read-out at that concentration, not a potency): 100%
For compound 3 the middle estimate is 20 percentage points below the measured one; low and high end bracket the measured number.
By their numbers in this assay, from the lowest: compound 1; then compounds 2 and 3 (each within the scatter of the next).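

In this assay, the change to 4-hydroxy-3-methoxybenzyl gives no change at the digits printed from compound 2 to compound 3 (within the scatter), so this saturated ring carbon accepts a benzyl group as well as 4-methoxyphenyl without a change in the number at the single concentration tested. The replacement of 2-phenylethenyl now gives a number 55 percentage points higher from compound 1 to compound 3 (beyond the scatter), so two different groups stand clear of compound 1 by the same margin, and the large gap is no longer tied to 4-methoxyphenyl alone. No available evidence bears on the reason for this result.

With compound 2 and compound 3 printing the same number at one concentration, any difference between them may lie out of reach of this read-out. From the compounds shown here alone, it remains open how an unsubstituted benzyl group, a longer alkyl chain, an amine or a carboxylic acid would behave on this carbon.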